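The source may report more compounds than this note shows. Statements on the series, on what has been measured and on what is new or still open speak of the compounds shown alone.

Of the compounds shown here, three built on one shared core have been measured in a functional assay on SW-620 cells (Homo sapiens) for cytotoxicity, read by sulforhodamine B assay, with a stated time of 48 h; a lower number here means a stronger inhibitor, a higher number a weaker inhibitor. Compound 1 `COc1ccc(C2=NO[C@]3(C2)C(=O)O[C@@H]2[C@H]3CC[C@H](C)[C@]3(O)C=CC(=O)[C@@]23C)cc1` gives 41000 nM. Compound 2 `C[C@H]1CC[C@@H]2[C@@H](OC(=O)[C@]23CC(c2ccccc2Br)=NO3)[C@]2(C)C(=O)C=C[C@@]12O` gives 44000 nM, and compound 3 `C[C@H]1CC[C@@H]2[C@@H](OC(=O)[C@]23CC(c2ccc(O)cc2)=NO3)[C@]2(C)C(=O)C=C[C@@]12O` gives 89000 nM. Among these three numbers compound 2 stands second highest: its nearest neighbour is compound 1, with a 1.1-fold higher number from compound 1 to compound 2 (0.03 log units; within the scatter), and its furthest is compound 3, with a 2.0-fold higher number from compound 2 to compound 3 (0.31 log units; beyond the scatter).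

Compound 4 `C[C@H]1CC[C@@H]2[C@@H](OC(=O)[C@]23CC(c2ccccc2F)=NO3)[C@]2(C)C(=O)C=C[C@@]12O` has not yet been measured. It differs from compound 2 by fluoro in place of bromo on an aromatic carbon. Going by the values given here, no measured step exchanges one halogen for another, so the closest guides are the other changes on the same aromatic ring: a 1.1-fold higher number from compound 1 to compound 2 (0.03 log units; within the scatter), which stayed within the scatter, and a 2.2-fold higher number from compound 1 to compound 3 (0.34 log units; beyond the scatter) together with a 2.0-fold higher number from compound 2 to compound 3 (0.31 log units; beyond the scatter), both modest. All three measured compounds sit in a narrow band, so the expectation for compound 4 is a step of a 1.0-fold higher number from compound 2 to compound 4 (0.01 log units; within the scatter), that is, nothing beyond the scatter. Compound 4 is therefore estimated at 45000 nM, with a range from 20000 nM to 100000 nM.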

Compound 4, half-maximal inhibitory concentration: 11000 nM
Compound 4: middle estimate off by 4.1-fold (0.61 log units), on the high side, and the stated range ends above it.
By their numbers in this assay, from the lowest: compound 4; then compounds 1 and 2 (each within the scatter of the next); then compound 3.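

In this assay, the halogen at this place on the ring matters: there is a 4.0-fold lower number from compound 2 to compound 4 (0.60 log units; beyond the scatter) when fluoro replaces bromo, a swap of one heavy atom for one heavy atom with no hydrogen-bond donor or acceptor gained or lost. The earlier changes on this ring had produced only small shifts, whereas the wider gaps of a 3.7-fold lower number from compound 1 to compound 4 (0.57 log units; beyond the scatter) and an 8.1-fold lower number from compound 3 to compound 4 (0.91 log units; beyond the scatter) now set 2-fluorophenyl apart as the strongest of the four. No measurement shown here accounts for this gain.

As far as these compounds go, whether chloro at the same place would give a number between those of compound 2 and compound 4 stays open. So does whether an amine or a nitrile on this ring could match or pass fluoro.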